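The compounds below may be only part of what the source reports. "The series", "measured", "known", "first", "only" and "open" are said of these compounds alone.

For the measured compounds named here, compound 1 `Cn1nc(-c2nnc(S)o2)cc1-c1ccc(C(F)(F)F)cc1` gives 68300 nM in a functional assay on Ehrlich cells (Mus musculus) for cytotoxicity, read by MTT assay, with a stated time of 24 h (on this read-out higher numbers stand for weaker inhibition and lower numbers for stronger inhibition), and stands highest of the two numbers measured so far, though only within the scatter of its neighbour. Compound 2 `Cn1nc(-c2nnc(SCc3cccc(Cl)c3Cl)o2)cc1-c1ccc(C(F)(F)F)cc1` gives 36800 nM in this assay. Compound 3 `Cn1nc(-c2nnc(SCCc3ccc(F)cc3)o2)cc1-c1ccc(C(F)(F)F)cc1` differs from compound 1 by 2-(4-fluorophenyl)ethyl in place of hydrogen on a sulfur. Going by the values given here, one measured step bears on this change: the same hydrogen on the sulfur replaced by 2,3-dichlorobenzyl gave a 1.9-fold lower number from compound 1 to compound 2 (0.27 log units; within the scatter). No step beyond the scatter is expected for compound 3 because a 1.9-fold lower number from compound 1 to compound 2 (0.27 log units; within the scatter) stayed within it. Compound 3 is therefore estimated at 40000 nM, with a range of 15000 nM to 100000 nM. This estimate means a 1.7-fold lower number from compound 1 to compound 3 (0.23 log units; within the scatter).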

Compound 3, half-maximal inhibitory concentration: 29200 nM
The estimate for compound 3 lay 1.4-fold (0.14 log units) above the measured number; measured number inside the range.
By their numbers in this assay, from the lowest: compounds 3, 2 and 1 (each within the scatter of the next, the first and the last beyond it).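

On the sulfur, a group in place of hydrogen now gives a step beyond the scatter in this assay, though a modest one: a 2.3-fold lower number from compound 1 to compound 3 (0.37 log units; beyond the scatter). Exchanging 2,3-dichlorophenyl for 4-fluorobenzyl on the saturated chain carbon bound to the sulfur leaves the two compounds within the scatter: a 1.3-fold lower number from compound 2 to compound 3 (0.10 log units; within the scatter). Nothing available explains either step. Going by these compounds, whether a chain ending in an amine or a carboxylic acid, rather than an aromatic ring of carbon, would keep or lose this step stays open. So does the effect of a longer chain on the sulfur.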